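A few compounds are considered here, and "the series" means these few. Any claim that something is new, unique, unknown or untested is made for them only; others in the source may bear on it.

Measured in a functional assay on Rec1 cells (Homo sapiens) for inhibition, read by luminescence and CellTiter-Glo, with a stated time of 72 h; a higher number here means a weaker inhibitor, a lower number a stronger inhibitor:
- Compound 1 `C=CC(=O)Nc1cccc(Cn2nc(-c3ccc(Oc4ccccc4)cc3)cc2C(=O)OCC)c1`: 3300 nM
- Compound 2 `C=CC(=O)Nc1cccc(Cn2nc(-c3ccc(Oc4ccccc4)cc3)cc2CO)c1`: 1300 nM

Of these two, compound 2 has the lower number and is the stronger inhibitor in this assay. Compound 3 `C=CC(=O)Nc1cccc(Cn2nc(-c3ccc(Oc4ccccc4)cc3)cc2C(=O)O)c1` carries carboxy in place of hydroxymethyl on an aromatic carbon. Among the measured compounds shown here, the only measured step on that carbon is a 2.5-fold lower number from compound 1 to compound 2 (0.40 log units; beyond the scatter), which is modest and replaces ethoxycarbonyl with hydroxymethyl. Compound 3 reverses that kind of change, since carboxy, like ethoxycarbonyl, contains a carbonyl, so a modest rise in the number is expected. The expected change is a 3.1-fold higher number from compound 2 to compound 3 (0.49 log units; beyond the scatter). For compound 3 the estimated value is 4000 nM, within an expected range of 1300 nM to 13000 nM.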

Compound 3, half-maximal inhibitory concentration: 33100 nM
The estimate for compound 3 lay 8.3-fold (0.92 log units) below the measured number; the measured number lies above the stated range.
By their numbers in this assay, from the lowest: compound 2; then compound 1; then compound 3.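

Replacing hydroxymethyl with carboxy on this aromatic carbon gives a 25-fold higher number from compound 2 to compound 3 (1.41 log units; beyond the scatter) and replacing ethyl with hydrogen on the oxygen next to the carbonyl group gives a 10-fold higher number from compound 1 to compound 3 (1.00 log units; beyond the scatter). The earlier compounds shown here showed only a modest step at this position, whereas these steps show that ethoxycarbonyl and carboxy are far from interchangeable here, even though both contain a carbonyl. Nothing available here explains the size of these steps. Still open, on these data alone, is how an amine, a methoxymethyl group or a primary amide on this carbon would compare with hydroxymethyl.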